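The compounds below may be only part of what the source reports. "The series", "measured", "known", "first", "only" and "open" are said of these compounds alone.

Measured so far in a functional assay on HTB-54 cells (Homo sapiens) for cytotoxicity, read by MTT assay, with a stated time of 72 h; a higher number here means a weaker inhibitor of growth, a lower number a stronger inhibitor of growth:
compound 1 `N#C[Se]c1ccc(NC(=O)Oc2ccc(F)cc2)cc1` gives 48400 nM
compound 2 `Cc1ccc(OC(=O)Nc2ccc([Se][Se]c3ccc(NC(=O)Oc4ccc(C)cc4)cc3)cc2)cc1` gives 57000 nM
compound 3 `O=C(Nc1ccc([Se][Se]c2ccc(NC(=O)Oc3ccc(F)cc3)cc2)cc1)Oc1ccc(F)cc1` gives 51800 nM

Compound 1 carries the lowest of the three numbers, yet compound 3 and compound 2 both lie within the usual scatter of it, so no order among the three can be read; the series is flat at these values.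

The next compound is compound 4 `COc1ccc(OC(=O)Nc2ccc([Se]C#N)cc2)cc1`, which differs from compound 1 in one place: methoxy in place of fluoro on an aromatic carbon. Among the measured compounds shown here, no step between measured compounds bears on this change, and the three measured values show no trend to extend. In this assay the expected step is a 1.0-fold higher number from compound 1 to compound 4 (0.01 log units; within the scatter), nothing beyond the scatter in either direction. Compound 4 is expected to give about 50000 nM in this assay, with a range from 25000 nM to 100000 nM.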

Compound 4, concentration for total growth inhibition: 48500 nM
Estimate against measurement, compound 4: 1.0-fold (0.01 log units) above; measured number inside the range.
By their numbers in this assay, from the lowest: compounds 1, 4, 3 and 2 (each within the scatter of the next).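

In this assay, the first single-place change measured in this series, methoxy in place of fluoro on an aromatic carbon, para to a large group, gives a 1.0-fold higher number from compound 1 to compound 4 (0.00 log units; within the scatter). At this position, the added heavy atom and hydrogen-bond acceptor of methoxy therefore come with no change beyond the scatter. No evidence on hand bears on this result.

From the compounds shown here alone, whether an amine, a carboxylic acid or a longer alkoxy chain at this position would move the number beyond the scatter remains open. Among the compounds shown here, the series so far gives no group here that does so.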